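This account rests on a few compounds, and the source may have more. Where it says the series, first, only, none or still open, it means among the compounds named here.

Measured so far in this series:
compound 1, `Fc1cncc(OC[C@@H]2CCN2)c1`, 0.076 nM;
compound 2, `Brc1cncc(OC[C@@H]2CCN2)c1`, 0.18 nM;
compound 3, `Fc1ccc(OC[C@H]2CCN2)cn1`, 0.066 nM.

All three were read in an assay on brain for binding affinity to Neuronal acetylcholine receptor; alpha4/beta2 (Rattus norvegicus), read by radioligand binding; on this read-out higher numbers stand for weaker inhibition and lower numbers for stronger inhibition. Compound 1 and compound 2 share one core and differ in a single spot: bromo in place of fluoro on an aromatic carbon. That change gave a 2.4-fold higher number from compound 1 to compound 2 (0.37 log units; beyond the scatter). Compound 3 is built from the same atoms as compound 1 joined differently; the difference between the two cores is not broken down here. Its value lies within the scatter of compound 1 and beyond the scatter of compound 2.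

Compound 4, `Brc1ccc(OC[C@H]2CCN2)cn1`, has not yet been measured. It differs from compound 3 as follows: bromo in place of fluoro on an aromatic carbon. Within the data shown here, this is the same kind of change as the one from compound 1 to compound 2, though not the same: in compound 4 the bromo sits next to the ring nitrogen and para to a group of 6 heavy atoms, whereas in compound 2 it sits two atoms from the ring nitrogen and meta to a group of 6 heavy atoms. In this assay compound 4 is expected to give 0.16 nM, with a likely range from 0.08 nM to 0.35 nM. The expected step is a 2.4-fold higher number from compound 3 to compound 4 (0.38 log units; beyond the scatter). This expectation rests on the measured step of a 2.4-fold higher number from compound 1 to compound 2 (0.37 log units; beyond the scatter). The place of the change is not the same in the two pairs, and the range is set wider on that account.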

Compound 4, inhibition constant: 0.17 nM
Compound 4: the middle estimate sits 1.1-fold (0.03 log units) below what was measured, within the range that was stated.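

In this assay, putting bromo in place of fluoro on an aromatic carbon gave a 2.6-fold higher number from compound 3 to compound 4 (0.41 log units; beyond the scatter), a modest step that lies beyond the scatter. Set beside the earlier step, the change carried over from one core to the other, even though the bromo stands next to the ring nitrogen in compound 4 and at a different place in compound 2, and the two steps cannot be told apart: the same change on two cores in this assay, a 2.4-fold higher number (0.37 log units; beyond the scatter) from compound 1 to compound 2 and a 2.6-fold higher number (0.41 log units; beyond the scatter) from compound 3 to compound 4, 1.1-fold (0.04 log units) apart, within the scatter of two such steps. Among these compounds, this agreement rests on only two cores and a single exchange of one halogen for another, so it does not show that the step would hold on any further core, and it does not explain why the two steps match.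

The compounds shown leave open how other groups at these places would read, such as chloro, methyl or a nitrile, since only fluoro and bromo appear here. They also leave open whether the same step would appear at any receptor other than the one read in this assay.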